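The source may report more compounds than this note shows. Statements on the series, on what has been measured and on what is new or still open speak of the compounds shown alone.

Measured compounds:
Compound 1 `CNc1ncnc2c1c(-c1ccoc1)cn2[C@@H]1O[C@H](CO)[C@@H](O)[C@H]1O` — in an ADME assay on MRC5 cells (Homo sapiens), read by MTT assay, with a stated time of 72 h (a lower number here means a stronger inhibitor, a higher number a weaker inhibitor), compound 1 gives > 100000 nM, a limit of the assay rather than a number.
Compound 2 `Cc1nc(N)c2c(-c3cccs3)cn([C@@H]3O[C@H](CO)[C@@H](O)[C@H]3O)c2n1` — in this assay compound 2 gives > 100000 nM, likewise a limit.
Compound 3 `CNc1ncnc2c1c(-c1ccco1)cn2[C@@H]1O[C@H](CO)[C@@H](O)[C@H]1O` — in this assay compound 3 gives 90800 nM.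

Compound 2 therefore stands at a limit, and so no number is known for it; of the three values shown, two sit there (the limit of > 100000 nM in this assay, at which 2 of the 3 values shown sit). Compound 4 `Cc1nc(N)c2c(-c3ccoc3)cn([C@@H]3O[C@H](CO)[C@@H](O)[C@H]3O)c2n1` is not yet measured. It differs from compound 2 in one place (furan-3-yl in place of thiophen-2-yl on an aromatic carbon).

Among the compounds with values here, only one measured step is available, and it concerns a different pair on a different core: an at least 1.1-fold lower number from compound 1 to compound 3 (0.04 log units; that floor lies within the scatter). It swaps one furan for another and is within the scatter, so it says nothing about trading a thiophen-2-yl for a furan-3-yl on the core of compound 2. Compound 1, which carries the same furan-3-yl group, also sits at the limit, so every comparison here rests on limits. No step beyond the scatter is expected. Compound 4 is thus estimated at 150000 nM, with a range from 60000 nM to 400000 nM. The step this estimate implies, a step that the limit leaves unreadable from compound 2 to compound 4, is expected to stay within the scatter, most likely ending again at a limit.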

Compound 4, half-maximal inhibitory concentration: > 100000 nM
Compound 4 was reported as a limit; the forecaster's own chance of this, stated with the estimate: 75%; the middle value does not contradict the limit.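

In this assay, compound 2 and compound 4 both end at a limit of the assay rather than a number, so no step can be read between them: the limit of > 100000 nM in this assay, at which 3 of the 4 values shown sit.

The compounds shown leave open whether thiophen-2-yl and furan-3-yl differ at all on the shared core of compound 2 and compound 4, and by how much.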